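This account rests on a few compounds, and the source may have more. Where it says the series, first, only, none or still open, it means among the compounds named here.

Compound 1 `CCOC(=O)CN(C)C(=O)c1ccc(C(CC)(CC)c2ccc(OCC(O)C(C)(C)C)c(C)c2)n1CC`: 9200 nM
Compound 2 `CCn1c(C(=O)NCC(OC)OC)ccc1C(CC)(CC)c1ccc(OCC(O)C(C)(C)C)c(C)c1`: > 50000 nM (a limit)

In a functional assay on MCF7 cells (Homo sapiens), read by MTT assay, with a stated time of 48 h (a higher number here means a weaker inhibitor, a lower number a stronger inhibitor), compound 2 stands at > 50000 nM, which is a limit of the assay and not a number. Compound 3 `CCn1c(C(=O)N(CCC#N)CCC#N)ccc1C(CC)(CC)c1ccc(OCC(O)C(C)(C)C)c(C)c1` changes compound 2 on a carbonyl carbon: a group of 9 heavy atoms (6 carbon, 3 nitrogen; no ring) in place of a group of 7 heavy atoms (4 carbon, 1 nitrogen, 2 oxygen; no ring), on a carbonyl carbon. For the measured compounds named here, the only measured step at this place is an at least 5.4-fold higher number from compound 1 to compound 2 (0.73 log units; beyond the scatter), which is beyond the scatter. Compound 1 at 9200 nM shows that a different group here can give a real number, so a modest fall in this assay is expected. Even so, a second limit is quite possible for compound 3. The expected step is an at least 1.7-fold lower number from compound 2 to compound 3 (0.25 log units; that floor lies within the scatter). For compound 3 the estimated value is 28000 nM, with an expected range of 10000 nM to 70000 nM.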

Compound 3, half-maximal inhibitory concentration: 480 nM
Compound 3: middle estimate off by 58-fold (1.77 log units), on the high side, and the stated range ends above it.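

In this assay, for the compounds shown here, the group on the carbonyl carbon moves the number over a much wider span than the earlier compounds showed: the group of 9 heavy atoms gives an at least 100-fold lower number from compound 2 to compound 3 (2.01 log units; beyond the scatter), and also a 19-fold lower number from compound 1 to compound 3 (1.28 log units; beyond the scatter). Only the step from compound 1 has a fixed size, since the step from compound 2 rests on a limit of the assay: the limit of > 50000 nM in this assay, at which 1 of the 3 values shown sits.

The compounds shown do not tell whether both nitrile-bearing chains are needed or whether one would do. Nor do they show whether a longer chain ending in nitrile, or an amine in place of each nitrile, would hold this level.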